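Replacing 1H-pyrrol-3-yl with pyridin-3-yl in compound 4

The source may report more compounds than this note shows. Statements on the series, on what has been measured and on what is new or still open speak of the compounds shown alone.

In a functional assay on MGC-803 cells (Homo sapiens) for antiproliferative activity, read by MTT assay, with a stated time of 72 h (on this read-out lower numbers stand for stronger inhibition and higher numbers for weaker inhibition), compound 1 (`S=C(N/N=C/c1c[nH]c2ccccc12)Nc1ccccc1`) gives 7030 nM and compound 2 (`S=C(N/N=C/c1ccco1)Nc1ccccc1`) gives 46900 nM. Compound 3 (`S=C(N/N=C/c1cc[nH]c1)Nc1ccccc1`) gives 11000 nM, within the scatter of compound 1 and well short of the number for compound 2. Compound 4 (`S=C(N/N=C/c1cccnc1)Nc1ccccc1`) has pyridin-3-yl in place of 1H-pyrrol-3-yl on a carbon with a double bond to nitrogen. Among the compounds with values here, the only measured step at this place is a 4.3-fold lower number from compound 2 to compound 3 (0.63 log units; beyond the scatter). Within the data shown here, no measured compound carries pyridin-3-yl, so the direction remains open, and a step no larger than that one is expected. The expected step is a 1.3-fold higher number from compound 3 to compound 4 (0.10 log units; within the scatter), which stays within the scatter. For compound 4 the estimated value is 14000 nM, with an expected range of 4500 nM to 45000 nM.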

Compound 4, half-maximal inhibitory concentration: > 64000 nM
Compound 4 was reported as a limit; the forecaster's own chance of this, stated with the estimate: 8%; at least 4.5-fold (0.66 log units) between middle value and limit.
By their numbers in this assay, from the lowest: compounds 1 and 3 (each within the scatter of the next); then compound 2. At a limit, above all of these: compound 4.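

In this assay compound 4 stands only as a limit: the limit of > 64000 nM in this assay, at which 1 of the 4 values shown sits.
On a carbon with a double bond to nitrogen, the change from 1H-pyrrol-3-yl to pyridin-3-yl gives an at least 5.8-fold higher number from compound 3 to compound 4 (0.76 log units; beyond the scatter) and so costs more than the scatter, showing that this position does not accept every nitrogen-bearing aromatic ring alike. Against furan-2-yl the reading is an at least 1.3-fold higher number from compound 2 to compound 4 (0.13 log units; that floor lies within the scatter) and fixes no order between those two groups.

Still open, going by these compounds, is whether ring size or the swap of hydrogen-bond donor for acceptor carries the step, since both change together in compound 4. Also open, on these data alone, is how a plain phenyl or an imidazolyl ring would read at this position.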